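This account rests on a few compounds, and the source may have more. Where it says the series, first, only, none or still open, it means among the compounds named here.

Compound 1 `Cc1c(C#N)c(NCCO)nc2nc(NCCO)nc(N)c12`: 31900 nM
Compound 2 `N#Cc1cc2c(N)ncnc2nc1Nc1ccc(S(N)(=O)=O)cc1`: 7800 nM
Compound 3 `N#Cc1cc2c(N)nc(NCCO)nc2nc1NCCO`: 6250 nM

These three compounds were tested in a functional assay on A-431 cells (Homo sapiens) for inhibition, read by sulforhodamine B assay, with a stated time of 2 days; on this read-out higher numbers stand for weaker inhibition of growth and lower numbers for stronger inhibition of growth. Compound 2, at 7800 nM, lies within the scatter of compound 3, at 6250 nM. The value of compound 1, 31900 nM, is clearly higher than that of compound 2.

Compound 4 `Cc1c(C#N)c(Nc2ccc(S(N)(=O)=O)cc2)nc2ncnc(N)c12` differs from compound 2 in one place: methyl in place of hydrogen on an aromatic carbon. This is methyl in place of hydrogen on an aromatic carbon, ortho to a cyano group.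

Within the data shown here, only one measured step bears on this exchange: a 5.1-fold lower number from compound 1 to compound 3 (0.71 log units; beyond the scatter). It runs the opposite way, removing the methyl, and it is modest but beyond the scatter. Read in reverse, it points to a higher number in this assay when the methyl enters. That pair carries other substituents than compound 2, however, so the size may not transfer in full, and a somewhat smaller rise is expected.

The expected change is a 2.6-fold higher number from compound 2 to compound 4 (0.41 log units; beyond the scatter). Compound 4 is estimated at 20000 nM, with an expected range of 7000 nM to 55000 nM.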

Compound 4, concentration for 50% growth inhibition: 2940 nM
Compound 4: the middle estimate sits 6.8-fold (0.83 log units) above what was measured; measured number outside the range, below it.
By their numbers in this assay, from the lowest: compound 4; then compounds 3 and 2 (each within the scatter of the next); then compound 1.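

In this assay, methyl in place of hydrogen on an aromatic carbon, ortho to a cyano group, gives a 2.7-fold lower number from compound 2 to compound 4 (0.42 log units; beyond the scatter). Here the methyl goes with stronger inhibition of growth, whereas in the only earlier pair it went with weaker inhibition. The exchange at this position therefore has no single direction across the compounds shown, and its outcome differs clearly with the core that carries it: the same change on two cores in this assay, a 5.1-fold lower number (0.71 log units; beyond the scatter) from compound 1 to compound 3 and a 2.7-fold higher number (0.42 log units; beyond the scatter) from compound 4 to compound 2, 14-fold (1.13 log units) apart, beyond the scatter of two such steps

Which of the differences between the two cores goes with this reversal remains open, as the two pairs differ in more than one place from each other. On these data alone, it is also open whether an ethyl group or a chlorine atom on this aromatic carbon would follow the methyl on the core of compound 4.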